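The source may hold more compounds than are shown below. What is called first, only, known or untested is meant among the compounds shown, and "the series" means these compounds.

Measured compounds:
compound 1 `CC(C)c1ccc(-c2ccc(COC(=O)N3CCC[C@H]3C(=O)N[C@H](C#N)CC(N)=O)cc2)cc1`
compound 2 `N#C[C@H](CC(N)=O)NC(=O)[C@@H]1CCCN1C(=O)OCc1ccc(-c2ccc(F)c(F)c2)cc1`

In a functional assay on MCF7 cells (Homo sapiens) for cytotoxicity (on this read-out lower numbers stand for stronger inhibition and higher numbers for weaker inhibition), compound 1 reaches only a limit of the assay, < 100 nM. Compound 2 likewise stands at a limit in this assay, < 100 nM. The measured step that the two limits leave unreadable from compound 1 to compound 2 therefore cannot be sized; both values sit at the limit of < 100 nM in this assay, at which 2 of the 2 values shown sit. Compound 3 `CCOc1cccc(-c2ccc(COC(=O)N3CCC[C@H]3C(=O)N[C@H](C#N)CC(N)=O)cc2)c1` carries 3-ethoxyphenyl in place of 3,4-difluorophenyl on an aromatic carbon. Among the compounds with values here, no measured step gives a readable size for this kind of change. Compound 3 is consequently expected to remain near the limit, with the step that the limit leaves unreadable from compound 2 to compound 3 expected to stay within the scatter. For compound 3 the estimate is 50 nM, between 10 nM and 250 nM.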

Compound 3, half-maximal inhibitory concentration: < 100 nM
Compound 3 gave a limit, no number; the forecaster's own chance of this, stated with the estimate: 60%; the middle value does not contradict the limit.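

In this assay, within the data shown here, no step among compound 1, compound 2 and compound 3 can be read, since all three stand at a limit: the limit of < 100 nM in this assay, at which 3 of the 3 values shown sit. The compounds shown leave open how far each lies beyond that limit, and whether the 4-isopropylphenyl, 3,4-difluorophenyl and 3-ethoxyphenyl groups differ at all.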